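The source may hold more compounds than are shown below. What is called first, only, known or untested is meant among the compounds shown, and "the series" means these compounds.

Measured: compound 1 `O=C(NC(=S)Nc1cccc(-c2nc3ccccc3[nH]2)c1)c1ccccc1`, > 10000 nM; compound 2 `CCOc1ccc(C(=O)NC(=S)Nc2cc(-c3nc4ccccc4[nH]3)ccc2C)cc1OCC`, "not determined" (no result reported).

In a functional assay on HUVEC cells (Homo sapiens) for cytotoxicity, read by WST assay, with a stated time of 48 h (a higher number here means a weaker inhibitor, a lower number a stronger inhibitor), compound 1 gives only a limit, > 10000 nM. Compound 2 carries no result in this assay, so compound 1 stands alone in the numbers, sitting at the limit of > 10000 nM in this assay, at which 1 of the 2 values shown sits. Compound 3 `O=C(NC(=S)Nc1cccc(-c2nc3ccccc3[nH]2)c1)c1ccc2c(c1)OCCO2` differs from compound 1 by 2,3-dihydro-1,4-benzodioxin-6-yl in place of phenyl on a carbonyl carbon. Within the data shown here, no measured step of this kind exists, so the size of the change cannot be read from data; the expectation is no step beyond the scatter in this assay. Compound 3 is expected at 15000 nM, within 5000 nM to 50000 nM, the estimated step being a step that the limit leaves unreadable from compound 1 to compound 3.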

Compound 3, half-maximal inhibitory concentration: 50 nM
For compound 3 the middle estimate is 300-fold (2.48 log units) above the measured one; the whole stated range lies above it.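

In this assay, the position on the carbonyl carbon responds strongly to this change: 2,3-dihydro-1,4-benzodioxin-6-yl in place of phenyl gives an at least 200-fold lower number from compound 1 to compound 3 (2.30 log units; beyond the scatter). The step has only a lower bound, because compound 1 is held at a limit: the limit of > 10000 nM in this assay, at which 1 of the 3 values shown sits. Within this single pair, the shared core alone does not set the read-out, and the group on the carbonyl carbon makes the difference.

The compounds shown do not separate the contribution of the two oxygen atoms from that of the added non-aromatic ring. Going by these compounds, how a single methoxy group or a morpholine on the phenyl ring would read remains open.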